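The source may hold more compounds than are shown below. What is called first, only, known or untested is meant among the compounds shown, and "the series" means these compounds.

Working notes on a small series tested in a functional assay on HT-29 cells (Homo sapiens) for antiproliferative activity, read by MTT assay, with a stated time of 72 h; a higher number here means a weaker inhibitor, a lower number a stronger inhibitor. Compound 1 (`Cc1ccccc1N1CCN(C2=CC(=O)c3cccc(O)c3C2=O)CC1`) gives 2800 nM, compound 2 (`O=C1C=C(N2CCN(c3ccccc3)CC2)C(=O)c2c(O)ccc(O)c21`) gives 2600 nM, and compound 3 (`O=C1C=C(N2CCC(c3ccccc3)CC2)C(=O)c2c(O)cccc21`) gives 5400 nM. Compound 3 stands within the scatter of compound 1, while its number is higher than that of compound 2 by a gap just beyond the scatter.

Compound 4 (`O=C1C=C(N2CCC(c3ccc(Cl)cc3)CC2)C(=O)c2c(O)cccc21`) differs from compound 3 in one place: chloro in place of hydrogen on an aromatic carbon, with chloro in place of hydrogen on an aromatic carbon, para to a large group, so that phenyl becomes 4-chlorophenyl.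

Among the compounds with values here, no measured pair differs in one place, so nothing sizes this change directly. Compound 2 at 2600 nM and compound 3 at 5400 nM lie only a narrow gap apart, so only a small move is expected, toward a lower number. The estimated change is a 1.4-fold lower number from compound 3 to compound 4 (0.15 log units; within the scatter), which is expected to stay within the scatter. For compound 4 the estimated value is 3800 nM, with an expected range of 1700 nM to 8000 nM.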

Compound 4, half-maximal inhibitory concentration: 6900 nM
Compound 4: middle estimate off by 1.8-fold (0.26 log units), on the low side; measured number inside the range.
By their numbers in this assay, from the lowest: compounds 2, 1, 3 and 4 (each within the scatter of the next, the first and the last beyond it).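

In this assay, within the data shown here, the first single-place step reads a 1.3-fold higher number from compound 3 to compound 4 (0.11 log units; within the scatter) and so stays within the scatter: phenyl and 4-chlorophenyl are not told apart here. Among these compounds, this position, para to a large group, therefore takes one added chlorine atom without a change this assay can resolve, something the earlier compounds, none differing in one place, could not show. No measurement at hand bears on why the number holds at this position.

Going by these compounds, whether another group at the same place, such as an amine, a carboxylic acid or a longer chain, would move the number beyond the scatter stays open. Also open, on these data alone, is whether chloro in place of hydrogen would read the same on the phenyl of compound 2.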